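Chloro position on the benzoyl ring: compound 1 to 3

The source may report more compounds than this note shows. Statements on the series, on what has been measured and on what is new or still open speak of the compounds shown alone.

Compound 1 `CC(/C=N/Nc1ccc([N+](=O)[O-])cc1)=N\NC(=O)c1ccc(Cl)cc1` is the reference of the pair. Among the compounds with values here, in a functional assay on cells (Splenocyte, Mus musculus, strain BALB/c) for inhibition, read by scintillation counting and thymidine incorporation, with a stated time of 72 h (on this read-out lower numbers stand for stronger inhibition and higher numbers for weaker inhibition), compound 1 gives 4200 nM, the only number in hand for the series. Within the data shown here, the one further value in hand, that of compound 2, is a limit. Compound 2 `CC(/C=N/Nc1ccc([N+](=O)[O-])cc1)=N\NC(=O)c1ccc(C(C)(C)C)cc1` carries tert-butyl in place of chloro on an aromatic carbon. For compound 2 the value > 12000 nM in this assay is a limit of the assay, not a number. The step of an at least 2.8-fold higher number from compound 1 to compound 2 (0.45 log units; beyond the scatter) therefore ends at the limit of > 12000 nM in this assay, at which 1 of the 2 values shown sits, and is known only as a lower bound.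

Compound 3 `CC(/C=N/Nc1ccc([N+](=O)[O-])cc1)=N\NC(=O)c1ccccc1Cl` is not yet measured. It differs from compound 1 by 2-chlorophenyl in place of 4-chlorophenyl on a carbonyl carbon. Among the measured compounds shown here, no measured step touches the same change: the step from compound 1 to compound 2 swaps the group on the ring, whereas here the same chlorine is kept and only the substitution pattern of the ring on the carbonyl carbon shifts. For the measured compounds named here, with no direct precedent, a step within the scatter or at most modest, in either direction, is expected for compound 3 in this assay, namely a 1.2-fold higher number from compound 1 to compound 3 (0.08 log units; within the scatter). Compound 3 is estimated at 5000 nM, with a range from 1800 nM to 14000 nM.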

Compound 3, half-maximal inhibitory concentration: > 12000 nM
Compound 3 gave a limit, no number; the forecaster's own chance of this, stated with the estimate: 25%; middle value at least 2.4-fold (0.38 log units) away from the limit.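

Moving the chlorine alone, with the same atoms in the group, already matters in this assay: the step is an at least 2.8-fold higher number from compound 1 to compound 3 (0.45 log units; beyond the scatter). Within the data shown here, until now the only change seen was the exchange of one group for another, tert-butyl for chloro, so the place of the chlorine on the ring attached to the carbonyl carbon now counts alongside the identity of the group. Compound 3 gives > 12000 nM, which is a limit of the assay and not a number, so the true size of the step stays unknown, and compound 1 remains the only compound with a number, both changes away from it ending at the same limit: the limit of > 12000 nM in this assay, at which 2 of the 3 values shown sit.

The compounds shown leave open whether fluoro, methyl, methoxy or an amine on this ring would keep a number in this read-out, and how plain phenyl compares with 4-chlorophenyl. They also leave open the other end of the molecule, since the nitro group is the same in all three compounds, and a nitrile or a carboxylic acid in its place could show whether that end matters as much as the ring on the carbonyl carbon.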